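Solubility notes: replacing the methylpiperazine on the oxazolidinone chain

This account rests on a few compounds, and the source may have more. Where it says the series, first, only, none or still open, it means among the compounds named here.

Compound 1 `CN1CCN(C[C@H]2CN(c3ccc(-n4cc(-c5ccccn5)cn4)c(F)c3)C(=O)O2)CC1` is the reference point of this small set. Going by the values given here, in a physicochemical assay for solubility, read by HPLC, with a stated time of 24 h (a lower number here means a less soluble compound, a higher number a more soluble compound), compound 1 gives 1690000 nM, the highest of the three numbers measured so far. Compound 2 `CC(=O)OC[C@H]1CN(c2ccc(-n3cc(-c4ccccn4)cn3)c(F)c2)C(=O)O1` gives 373000 nM and compound 3 `O=CNC[C@H]1CN(c2ccc(-n3cc(-c4ccccn4)cn3)c(F)c2)C(=O)O1` gives 217000 nM. The two measured steps away from compound 1 both move downward: a 4.5-fold lower number from compound 1 to compound 2 (0.66 log units; beyond the scatter) and a 7.8-fold lower number from compound 1 to compound 3 (0.89 log units; beyond the scatter). Between the two replacements themselves the gap is small, a 1.7-fold lower number from compound 2 to compound 3 (0.24 log units; within the scatter).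

Compound 4 `CCNC(=O)NC[C@H]1CN(c2ccc(-n3cc(-c4ccccn4)cn3)c(F)c2)C(=O)O1` differs from compound 1 in the same place: (ethylcarbamoyl)amino in place of 4-methylpiperazin-1-yl on a saturated chain carbon bound to a saturated ring carbon. The step is of the same kind as the two measured ones, a neutral group without a ring replacing the 4-methylpiperazin-1-yl, so those steps bear directly on it. Both were modest and downward and beyond the scatter, and the entering (ethylcarbamoyl)amino is closer in character to the formylamino of compound 3 than to the acetoxy of compound 2. A downward step of at least the size of a 7.8-fold lower number from compound 1 to compound 3 (0.89 log units; beyond the scatter) is therefore expected for compound 4, and the expected step reads an 11-fold lower number from compound 1 to compound 4 (1.05 log units; beyond the scatter). For compound 4 the estimate in this assay is 150000 nM, with a range from 60000 nM to 400000 nM.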

Compound 4, solubility: 222000 nM
Compound 4: the middle estimate sits 1.5-fold (0.17 log units) below what was measured; the measured number falls inside the stated range.
By their numbers in this assay, from the lowest: compounds 3, 4 and 2 (each within the scatter of the next); then compound 1.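

In this assay, going by these compounds alone, the (ethylcarbamoyl)amino group in place of 4-methylpiperazin-1-yl gives a 7.6-fold lower number from compound 1 to compound 4 (0.88 log units; beyond the scatter) and so joins acetoxy and formylamino: all three replacements at this place stand beyond the scatter under compound 1, with no compound here going against that. Adding ethylamino in place of hydrogen on the carbonyl carbon does not separate the compounds, with a 1.0-fold higher number from compound 3 to compound 4 (0.01 log units; within the scatter) and, against the ester, a 1.7-fold lower number from compound 2 to compound 4 (0.23 log units; within the scatter), so compounds 2, 3 and 4 form a single level within the scatter, whichever of these three groups is attached. Nothing measured here accounts for that level or for the gap to compound 1.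

On these data alone, whether an open-chain amine such as dimethylamino or a ring such as morpholine, on a saturated chain carbon bound to a saturated ring carbon, would stay with compound 1 or fall to the level of compounds 2, 3 and 4 remains open. As far as these compounds go, a carboxylic acid at this place, or a longer chain such as butylamino on the carbonyl carbon of compound 4, also lies outside these compounds, so how far that level extends is unknown.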